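The compounds below may be only part of what the source reports. "The series", "measured", "known", "first", "only" and "open" are said of these compounds alone.

Measured in a functional assay on G-361 cells (Homo sapiens) for cytotoxicity, read by sulforhodamine B assay; a lower number here means a stronger inhibitor of growth, a higher number a weaker inhibitor of growth:

compound 1 , `CCCNc1nc(C)nc2c1cnn2-c1ccccc1`, > 100000 nM
compound 2 , `Cc1nc(NC(C)C)c2cnn(-c3ccccc3)c2n1`, > 100000 nM

Compound 1 stands only at a limit of this assay, not at a number; it gives no readable position of its own, and the limit of > 100000 nM in this assay, at which 2 of the 2 values shown sit, holds both values shown. Compound 2 likewise sits at that limit. For the measured compounds named here, the one measured step, a step that the two limits leave unreadable from compound 1 to compound 2, is therefore unreadable in size and direction, and nothing else in this assay is known for the series.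

Compound 3 , `Cc1nc(Nc2ccccc2)c2cnn(-c3ccccc3)c2n1`, is not yet measured. Against compound 1 it carries phenyl in place of propyl on a nitrogen on an aromatic ring. Going by the values given here, no measured step bears on this change; the only step recorded says nothing about it. The expectation for compound 3 is that it stays at or near the limit of this assay, with a step of a number no higher from compound 1 to compound 3 (the limit leaves the size open) expected to show no readable gain. The estimate for compound 3 is 100000 nM, with a range from 20000 nM to 300000 nM.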

Compound 3, concentration for total growth inhibition: > 100000 nM
Compound 3: no number, only a limit (the forecaster's own chance of this, stated with the estimate: 70%); the middle value lies on the limit itself.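

In this assay no new step can be read, since compound 1, compound 2 and compound 3 all give only a limit and no number: the limit of > 100000 nM in this assay, at which 3 of the 3 values shown sit. The compounds shown leave open whether any group on that nitrogen of the shared core gives a readable value.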